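Methylamino to dimethylamino on the thiophene analogue of the shared core

This account rests on a few compounds, and the source may have more. Where it says the series, first, only, none or still open, it means among the compounds named here.

Measured compounds:
compound 1, `CNc1ncnc2c1c(-c1ccccc1)cn2[C@@H]1O[C@H](CO)[C@@H](O)[C@H]1O`, > 20000 nM
compound 2, `CNc1ncnc2c1c(-c1cccs1)cn2[C@@H]1O[C@H](CO)[C@@H](O)[C@H]1O`, > 20000 nM
compound 3, `C#Cc1cn([C@@H]2O[C@H](CO)[C@@H](O)[C@H]2O)c2ncnc(NC)c12`, 1380 nM

In a functional assay on K562 cells (Homo sapiens), read by MTT assay, with a stated time of 72 h (on this read-out higher numbers stand for weaker inhibition and lower numbers for stronger inhibition), compound 1 gives > 20000 nM, which is a limit of the assay and not a number. Compound 2 likewise gives > 20000 nM in this assay, again a limit. Among the measured compounds shown here, compound 3 is the only one with a number, giving 1380 nM in this assay. Accordingly a step that the two limits leave unreadable from compound 1 to compound 2, whereas an at least 14-fold lower number from compound 1 to compound 3 (1.16 log units; beyond the scatter) and an at least 14-fold lower number from compound 2 to compound 3 (1.16 log units; beyond the scatter). Compound 2 thus stands at the limit of > 20000 nM in this assay, at which 2 of the 3 values shown sit, together with compound 1, with compound 3 alone readable.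

Compound 4, `CN(C)c1ncnc2c1c(-c1cccs1)cn2[C@@H]1O[C@H](CO)[C@@H](O)[C@H]1O`, differs from compound 2 by methyl in place of hydrogen on a nitrogen on an aromatic ring. All three measured steps change the group on the aromatic carbon; none touches the nitrogen, so none bears on this change, and no size of step beyond the scatter can be grounded in either direction for this assay. The expectation is that compound 4 remains at the limit, estimated at 30000 nM with a range from 15000 nM to 60000 nM. The step so expected reads a step that the limit leaves unreadable from compound 2 to compound 4.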

Compound 4, half-maximal inhibitory concentration: > 20000 nM
Compound 4: only a limit was reported; the forecaster's own chance of this, stated with the estimate: 85%; the middle value lies beyond the limit too.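

Compound 4 gives > 20000 nM in this assay, a limit of the assay and not a number. Among the compounds shown here, compound 2 also sits at a limit, so no step between compound 2 and compound 4 can be read. Open remains what methylamino to dimethylamino does where a readable value exists, as in compound 3.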